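A few compounds are considered here, and "the series" means these few. Any claim that something is new, unique, unknown or untested is made for them only; others in the source may bear on it.

Working notes on the series in a functional assay on RPMI8266 cells (Homo sapiens) for cytotoxicity, read by sulforhodamine B assay, with a stated time of 48 h, tested at 10 uM; a higher number here means a weaker effect of the compound at the concentration tested, a lower number a stronger effect. Of the compounds shown here, two carry numbers so far. Compound 1, `Cc1cc(O)cc(-c2nn(CC#N)cc2-c2ccnc(-c3ccc(Oc4ccccc4)cc3)c2)c1`, gives -14% in this assay. Compound 2, `COc1cc(C)cc(-c2nn(CC#N)cc2-c2ccnc(-c3ccc(N(C)C)cc3)c2)c1`, gives -28% in this assay, which is the lowest of the two numbers; the nearest number is that of compound 1, and the gap between the two is larger than the usual scatter of this assay.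

Compound 3, `Cc1cc(O)cc(-c2nn(CC#N)cc2-c2ccnc(-c3ccc(N(C)C)cc3)c2)c1`, has not yet been measured in this assay. It differs from compound 2 in one place: hydrogen in place of methyl on an oxygen on an aromatic ring. Read one bond further out, methoxy becomes hydroxy, so 3-methoxy-5-methylphenyl becomes 3-hydroxy-5-methylphenyl. Among the compounds with values here, no measured pair shows this change on its own, so no step for it can be drawn; compound 1 also carries the hydroxy, but it differs from compound 2 in a second place as well, and its number says nothing on its own about this change. The step from compound 2 to compound 3 in this assay is therefore expected to be small, most likely within the scatter or just beyond it, and if anything towards a higher number; the expected step is a number 8 percentage points higher from compound 2 to compound 3 (within the scatter). For compound 3 the estimate in this assay is -20%, within a range from -42% to 2%.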

Compound 3, a percentage reported as activity, at one concentration (the size of the read-out at that concentration, not a potency): -28%
Compound 3: middle estimate off by 8 percentage points, on the high side; measured number inside the range.
By their numbers in this assay, from the lowest: compounds 2 and 3 (each within the scatter of the next); then compound 1.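

In this assay the change from methoxy to hydroxy on the 3-methoxy-5-methylphenyl ring gives no change at the digits printed from compound 2 to compound 3 (within the scatter), so with dimethylamino held constant, this oxygen carries either methyl or hydrogen without a step that can be told from the scatter. Compound 3 also supplies the first pair differing in one place at the other substituent, where dimethylamino in place of phenoxy gives a number 14 percentage points lower from compound 1 to compound 3 (beyond the scatter), so the gap seen earlier between compound 1 and compound 2 can now be read as a change at that aromatic carbon, with the hydroxy held constant. Nothing in hand explains either step.

The compounds shown leave open whether the reading holds with a longer chain such as ethoxy on this oxygen, or with an amine or a carboxylic acid in place of the hydroxy. They also leave open whether methoxy and hydroxy remain level with phenoxy in place of dimethylamino, and how a smaller amine such as methylamino would read at that aromatic carbon.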